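Aryl variation at the saturated ring carbon

This account rests on a few compounds, and the source may have more. Where it says the series, first, only, none or still open, it means among the compounds named here.

Compound 2 `N#CC1=C(N)N(c2ccc(S(N)(=O)=O)cc2)C2=C(CCCC2)C1c1ccccc1O` gives 40% in a functional assay on Ehrlich cells (Mus musculus) for cytotoxicity, read by trypan blue exclusion, with a stated time of 2 h, tested at 25 ug/mL (on this read-out higher numbers stand for a stronger effect at the one concentration tested and lower numbers for a weaker effect), and sits in the middle of the three numbers: compound 3 `N#CC1=C(N)N(c2ccc(S(N)(=O)=O)cc2)C2=C(CCCC2)C1c1ccc(O)cc1` is nearest at 42%, compound 1 `Cc1ccc(C2C(C#N)=C(N)N(c3ccc(S(N)(=O)=O)cc3)C3=C2CCCC3)cc1` furthest at 30%, both gaps within the scatter. Compound 4 `N#CC1=C(N)N(c2ccc(S(N)(=O)=O)cc2)C2=C(CCCC2)C1c1ccc(Cl)cc1Cl` differs from compound 2 by 2,4-dichlorophenyl in place of 2-hydroxyphenyl on a saturated ring carbon. The steps that touch the same saturated ring carbon are a number 10 percentage points higher from compound 1 to compound 2 (within the scatter) and a number 2 percentage points higher from compound 2 to compound 3 (within the scatter); only a number 12 percentage points higher from compound 1 to compound 3 (beyond the scatter) lies beyond the scatter. Among the measured compounds shown here, no measured step introduces chlorine or removes the hydroxy group, so the expected step is a number 4 percentage points lower from compound 2 to compound 4 (within the scatter), none beyond the scatter. Compound 4 is therefore estimated at 36% in this assay, with a range from 22% to 50%.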

Compound 4, a percentage reported as activity, at one concentration (the size of the read-out at that concentration, not a potency): 50%
Compound 4: the middle estimate sits 14 percentage points below what was measured; the measured number falls inside the stated range.
By their numbers in this assay, from the lowest: compounds 1, 2, 3 and 4 (each within the scatter of the next, the first and the last beyond it).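

In this assay the saturated ring carbon carries 2,4-dichlorophenyl, with no hydroxy group, without a change that can be told apart from the hydroxyphenyl compounds: a number 10 percentage points higher from compound 2 to compound 4 (within the scatter) and a number 8 percentage points higher from compound 3 to compound 4 (within the scatter) both stay within the scatter. Against 4-methylphenyl the reading differs, with a number 20 percentage points higher from compound 1 to compound 4 (beyond the scatter) as a second step out of compound 1 that clears the scatter. Nothing available explains these steps.

Open, from the compounds shown here alone, is whether a single chlorine, as in 4-chlorophenyl, gives the same number as two. Also open, going by these compounds, is how an amine or a carboxylic acid on this aromatic ring, or a cyclohexyl group replacing it, would read.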